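A methyl in place of a methoxy

This account rests on a few compounds, and the source may have more. Where it says the series, first, only, none or still open, it means among the compounds named here.

Measured so far in a functional assay on PC-3 cells (Homo sapiens) for cytotoxicity, read by MTT assay, with a stated time of 72 h (on this read-out higher numbers stand for weaker inhibition and lower numbers for stronger inhibition), and listed here:
compound 1 `CNC(=O)c1cc(Oc2ccc(NC(=O)c3nccc(-c4ccc(OC)cc4)n3)cc2F)ccn1` gives 24300 nM as a number
compound 2 `CNC(=O)c1cc(Oc2ccc(NC(=O)c3nccc(-c4ccc(OC)cc4)n3)cc2)ccn1` gives 14200 nM as a number
compound 3 `CNC(=O)c1cc(Oc2ccc(NC(=O)c3cc(-c4ccc(F)cc4)ncn3)cc2F)ccn1` gives > 100000 nM as a limit

Among the measured compounds shown here, only two of these three compounds carry a true number, and the gap between them is a 1.7-fold lower number from compound 1 to compound 2 (0.23 log units; within the scatter) so compound 1 cannot be set apart from its one neighbour. Compound 3 has a limit only and not a number, so it offers no size of step to reason from.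

Compound 4 `CNC(=O)c1cc(Oc2ccc(NC(=O)c3nccc(-c4ccc(C)cc4)n3)cc2F)ccn1` departs from compound 1 at one place, methyl in place of methoxy on an aromatic carbon with methyl in place of methoxy on an aromatic carbon, so that 4-methoxyphenyl becomes 4-methylphenyl. For the measured compounds named here, no measured step touches this group. Going by the values given here, the only single-place step at hand is a 1.7-fold lower number from compound 1 to compound 2 (0.23 log units; within the scatter) and it puts hydrogen in place of fluoro on an aromatic carbon, so it bears on the new change only indirectly, as one small step. No step beyond the scatter is therefore expected in this assay and no direction can be named. The expected step is a 1.0-fold lower number from compound 1 to compound 4 (0.01 log units; within the scatter) and it remains an estimate. Compound 4 is estimated at 24000 nM with an expected range of 9000 nM to 60000 nM for a measurement still to come.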

Compound 4, half-maximal inhibitory concentration: 28400 nM
For compound 4 the middle estimate is 1.2-fold (0.07 log units) below the measured one; the measured number falls inside the stated range.
By their numbers in this assay, from the lowest: compounds 2, 1 and 4 (each within the scatter of the next). At a limit, above all of these: compound 3.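

In this assay, the change from 4-methoxyphenyl to 4-methylphenyl on the aromatic carbon para to a large group gives a step within the scatter (a 1.2-fold higher number from compound 1 to compound 4 (0.07 log units; within the scatter)), the only step shown at this position. Among the compounds shown here, compound 1 and compound 4 therefore cannot be set apart, even though the methoxy, with its oxygen and its one hydrogen-bond acceptor, gives way to a methyl with neither; the earlier compounds, which all keep the methoxy or carry a different aryl group, could not show this. The one other readable step, which exchanges a fluoro for hydrogen elsewhere in the molecule, is also within the scatter (a 1.7-fold lower number from compound 1 to compound 2 (0.23 log units; within the scatter)), and nothing shown gives a reason for the step at this position.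

The compounds shown leave open whether any group at this position can move the number beyond the scatter, since only methoxy and methyl can be compared here on the shared core. An unsubstituted phenyl, a chloro, a trifluoromethyl, an amine or a carboxylic acid in the same place would test how far this result extends.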